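From Chloro to Nitro: Compound 2 to Compound 4

A few compounds are considered here, and "the series" means these few. Any claim that something is new, unique, unknown or untested is made for them only; others in the source may bear on it.

Of the compounds shown here, three have been measured in a functional assay on MDA-MB-231 cells (Homo sapiens) for inhibition, read by MTT assay, with a stated time of 24 h, tested at 100 uM; a lower number here means less inhibition, a higher number more inhibition at the concentration tested (going by the name of the read-out). Compound 1 `O=C(N/N=C/C1CCCCC1)c1ccc(O[C@@H]2O[C@H](CO)[C@@H](O)[C@H](O)[C@H]2O)cc1` gives 0.88% in this assay, compound 2 `O=C(N/N=C/c1ccc(Cl)cc1)c1ccc(O[C@@H]2O[C@H](CO)[C@@H](O)[C@H](O)[C@H]2O)cc1` gives 2.26%, and compound 3 `CC(=O)OC[C@H]1O[C@@H](Oc2ccc(-c3nnc(-c4ccc([N+](=O)[O-])cc4)o3)cc2)[C@H](OC(C)=O)[C@@H](OC(C)=O)[C@@H]1OC(C)=O` gives 58%. Compound 2 therefore stands second highest of the three numbers, with compound 1 as its nearest neighbour and compound 3 far above it. Among the compounds with values here, the one single-point step measured so far, a number 1.4 percentage points higher from compound 1 to compound 2 (within the scatter), stays within the scatter.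

Compound 4 `O=C(N/N=C/c1ccc([N+](=O)[O-])cc1)c1ccc(O[C@@H]2O[C@H](CO)[C@@H](O)[C@H](O)[C@H]2O)cc1` differs from compound 2 as follows: nitro in place of chloro on an aromatic carbon; read one bond further out, 4-chlorophenyl becomes 4-nitrophenyl. Within the data shown here, no measured step swaps a chloro for a nitro, so nothing bears directly on this change. Among the measured compounds shown here, compound 3 also carries a nitro group, but on a different core, and its value shows only that a high number is reachable in this assay, not a step. With no relevant step beyond the scatter, compound 4 is expected to show a number 2.7 percentage points higher from compound 2 to compound 4 (within the scatter). Compound 4 is therefore estimated at 5%, within a range from 0% to 20%.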

Compound 4, a percentage reported as inhibition, at one concentration (the size of the read-out at that concentration, not a potency): 7.12%
For compound 4 the middle estimate is 2.1 percentage points below the measured one; low and high end bracket the measured number.
By their numbers in this assay, from the lowest: compounds 1, 2 and 4 (each within the scatter of the next); then compound 3.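

Within the data shown here, with nitro in place of chloro on the aromatic carbon, para to a large group, this assay shows a number 4.9 percentage points higher from compound 2 to compound 4 (within the scatter) and so gives the first direct reading of this exchange: three heavy atoms and two hydrogen-bond acceptors entering for one chlorine do not carry the number beyond the scatter. The wider swap of cyclohexyl for 4-nitrophenyl gives a number 6.2 percentage points higher from compound 1 to compound 4 (within the scatter) and also stays inside it, so compounds 1, 2 and 4 cannot be told apart by this read-out. Nothing available bears on why the exchange has so small an effect.

On these data alone, whether an amine or a carboxylic acid on that same aromatic carbon would lift the number beyond the scatter remains open. Compound 3 differs from these three in more than one place, so its much higher value cannot be traced to any single change.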